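A few compounds are considered here, and "the series" means these few. Any claim that something is new, unique, unknown or untested is made for them only; others in the source may bear on it.

Compound 1 (`Clc1cccc(/N=N/N2CCCCC2)c1`) stands at the edge of what can be read here. In an ADME assay on BHK-21 cells (Mesocricetus auratus) for cytotoxicity, read by MTT assay, with a stated time of 96 h (on this read-out lower numbers stand for higher toxicity in this test and higher numbers for lower toxicity in this test), compound 1 gives > 100000 nM, which is a limit and not a number. Compound 2 (`CN(/N=N/c1cccc([N+](=O)[O-])c1)c1ccccc1`) gives > 100000 nM, which is also a limit. This is all that has been measured so far: the limit of > 100000 nM in this assay, at which 2 of the 2 values shown sit. Among the measured compounds shown here, no step between measured compounds is available, so nothing yet shows how a structural change moves the read-out.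

The next compound, compound 3 (`O=[N+]([O-])c1cccc(/N=N/N2CCCCC2)c1`), differs from compound 1 at one place: nitro in place of chloro on an aromatic carbon. In words, it has nitro in place of chloro on an aromatic carbon, meta to a group of 8 heavy atoms, and the rest of the core of compound 1 is kept. The expectation rests on the limit of compound 1, > 100000 nM.

The expected change in this assay is a number no higher from compound 1 to compound 3 (the limit leaves the size open), with none beyond the scatter expected in either direction, and a report at the same limit is the likeliest outcome. For compound 3, the estimated half-maximal cytotoxic concentration is 100000 nM, with an expected range of 40000 nM to 150000 nM.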

Compound 3, half-maximal cytotoxic concentration: > 100000 nM
Compound 3: no number, only a limit; the forecaster's own chance of this, stated with the estimate: 75%; the middle value lies on the limit itself.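

Among the compounds shown here, compound 1 and compound 3 both end at a limit in this assay and not at a number, so no step between them can be read, and the size of any effect of nitro in place of chloro stays unknown. The compounds shown leave open whether any structural change moves this read-out, as all values share one limit: the limit of > 100000 nM in this assay, at which 3 of the 3 values shown sit.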